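The compounds below may be only part of what the source reports. "The series", "measured", "known", "first", "only" and "open" are said of these compounds alone.

Of the compounds shown here, two have so far been measured in a functional assay on 4T1 cells (Mus musculus) for cytotoxicity, read by MTT assay, with a stated time of 24 h; on this read-out lower numbers stand for stronger inhibition and higher numbers for weaker inhibition. Compound 1 `O=C1/C(=C/c2ccccc2F)CN(Cc2cn(Cc3ccc(F)cc3)nn2)C/C1=C\c1ccccc1F` gives 6400 nM, and compound 2 `Cc1ccc(/C=C2\CN(C(=S)SCc3cn(Cc4ccccc4F)nn3)C/C(=C\c3ccc(C)cc3)C2=O)cc1` gives 28400 nM. Of the two numbers, compound 2 holds the higher one, which in this assay means the weaker inhibition of cell growth, and its gap to compound 1 lies beyond the usual scatter of repeated measurements. Among the compounds with values here, compound 1 and compound 2 differ in several places at once, so their two values show a gap but no single step that can be tied to one change.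

Compound 3 `Cc1ccc(/C=C2\CN(C(=S)SCc3cn(Cc4cccc(Cl)c4)nn3)C/C(=C\c3ccc(C)cc3)C2=O)cc1` differs from compound 2 in one place only: 3-chlorophenyl in place of 2-fluorophenyl on a saturated chain carbon bound to an aromatic nitrogen. Read one bond further out, the same difference is 2-fluorobenzyl to 3-chlorobenzyl. Within the data shown here, no measured pair in this set shows such a swap of one halogenated ring for another, so the expected step in this assay for compound 3 is none beyond the scatter, with no clear direction. Compound 3 is therefore estimated at 25000 nM, within a range from 10000 nM to 60000 nM, an expected step of a 1.1-fold lower number from compound 2 to compound 3 (0.06 log units; within the scatter).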

Compound 3, half-maximal inhibitory concentration: 53400 nM
Compound 3: middle estimate off by 2.1-fold (0.33 log units), on the low side; low and high end bracket the measured number.
By their numbers in this assay, from the lowest: compound 1; then compounds 2 and 3 (each within the scatter of the next).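

Within the data shown here, the swap of 2-fluorobenzyl for 3-chlorobenzyl in this assay gives a 1.9-fold higher number from compound 2 to compound 3 (0.27 log units; within the scatter) and is the first change in this set that can be read on its own. At this place, on a saturated chain carbon bound to an aromatic nitrogen, the 3-chlorophenyl group can therefore stand in for the 2-fluorophenyl group without a change that rises above the usual scatter of repeated measurements, although this single pair cannot separate the change of halogen from the change in where it sits on the ring. No measurement at hand speaks to why the two values lie so close.

A 3-fluorobenzyl group would pull those two parts of the change apart, since it would keep the ring place of compound 3 while carrying the halogen of compound 2. Going by these compounds, it also remains open how far this tolerance reaches, for example whether the same place would accept an unsubstituted benzyl group, a 3-methoxybenzyl group or a chain ending in an amine, all of them further from the two halogenated rings compared here.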